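The source may report more compounds than this note shows. Statements on the series, on what has been measured and on what is new or still open speak of the compounds shown alone.

Measured so far:
Compound 1 `CCNC(=O)c1cnc(N2CCN(C3CCN(Cc4ccc(Cl)cc4)CC3)[C@@H](CC)C2)c(Cl)c1`: 202 ng.h/mL
Compound 2 `CC[C@H]1CN(c2ncc(C(N)=O)nc2C(F)(F)F)CCN1C1CCN(C(=O)c2ccc(Cl)nc2N)CC1`: 8280 ng.h/mL

In an ADME assay on the whole organism for pharmacokinetics, with Rattus norvegicus as the target, with a stated time of 6 h, at a dose of 10 mg/kg by the oral route (on this read-out lower numbers stand for lower exposure and higher numbers for higher exposure at the dose given), compound 2 gives 8280 ng.h/mL, the higher of the two numbers, and compound 1 lies below it by a gap beyond the usual scatter. Compound 3 `CC[C@H]1CN(c2ncc(C(=O)NC)nc2C(F)(F)F)CCN1C1CCN(C(=O)c2ccc(Cl)nc2N)CC1` has not yet been measured. It differs from compound 2 in one place: methyl in place of hydrogen on an amide-type nitrogen, which is methyl in place of hydrogen on an amide-type nitrogen. The two measured compounds differ in more than one place, so the data offer no direct guide to this single change. With so small an edit, only a slight fall is expected, one that stays within the scatter. The expected step is a 1.7-fold lower number from compound 2 to compound 3 (0.22 log units; within the scatter). In this assay, the estimated value for compound 3 is 5000 ng.h/mL, with an expected range from 1700 ng.h/mL to 14000 ng.h/mL.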

Compound 3, area under the concentration-time curve: 3550 ng.h/mL
The estimate for compound 3 lay 1.4-fold (0.15 log units) above the measured number, and the stated range covers the measured number.
By their numbers in this assay, from the lowest: compound 1; then compound 3; then compound 2.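

In this assay the change of the amide hydrogen to methyl, which turns carbamoyl into methylcarbamoyl, gives a 2.3-fold lower number from compound 2 to compound 3 (0.37 log units; beyond the scatter) and so counts as a modest step, yet one beyond the usual scatter. Among the compounds shown here, this is the first comparison here between compounds that differ in one place only, and it shows that oral exposure can respond to a single added carbon on this amide-type nitrogen. No measurement at hand bears on the reason for this fall.

As far as these compounds go, it remains open whether a longer chain such as ethyl on this nitrogen, or a second methyl on it, would move the number further in the same direction. Also open, from the compounds shown here alone, is how a carboxylic acid or a nitrile in place of the whole amide would fare.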